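The source may hold more compounds than are shown below. What is called first, only, known or untested is meant among the compounds shown, and "the series" means these compounds.

Compound 1 `CC(C)NCc1nnc(-c2ccccc2-c2ccccc2)s1` stands second highest of the three numbers in a functional assay on the whole organism with Mus musculus as the target (a higher number here means that more compound is needed for the effect, a lower number that less compound is needed), where compound 1 gives 23 mg/kg. Its nearest neighbour is compound 2 `NCc1nnc(-c2ccccc2-c2ccccc2)s1`, which in this assay gives 20 mg/kg; the furthest is compound 3 `NCc1nnc(Cc2ccccc2)s1`, which gives 110 mg/kg. Compound 4 `CN(C)Cc1nnc(-c2ccccc2-c2ccccc2)s1` differs from compound 1 in one place: dimethylamino in place of isopropylamino on a saturated chain carbon bound to an aromatic carbon. Among the measured compounds shown here, only one measured step bears on this change, the one that also alters the group on the amine nitrogen: a 1.2-fold lower number from compound 1 to compound 2 (0.06 log units; within the scatter). Since that change left the number essentially where it was, the step from compound 1 to compound 4 is expected to stay within the scatter as well, with no clear direction. Compound 4 is therefore estimated at 23 mg/kg, within a range from 10 mg/kg to 55 mg/kg. The expected shift is no change at the digits printed from compound 1 to compound 4 (within the scatter).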

Compound 4, dose for half-maximal effect: 32 mg/kg
The estimate for compound 4 lay 1.4-fold (0.14 log units) below the measured number, within the range that was stated.
By their numbers in this assay, from the lowest: compounds 2, 1 and 4 (each within the scatter of the next); then compound 3.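

In this assay, dimethylamino on this saturated chain carbon gives a 1.4-fold higher number from compound 1 to compound 4 (0.14 log units; within the scatter) and a 1.6-fold higher number from compound 2 to compound 4 (0.20 log units; within the scatter), so amino, isopropylamino and dimethylamino all lie within the scatter of one another at this place. Dimethylamino has 0 hydrogen-bond donors where isopropylamino has 1, so among these compounds, the hydrogen on that nitrogen is not required to keep the number in this range. No other measurement here helps to explain this result. Going by these compounds, whether a longer chain on this nitrogen would stay within the scatter remains open, as does what an amide or a carboxylic acid would do in place of the amine.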